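Swapping a phenoxy for a tert-butylphenyl on a quinoline core

The source may report more compounds than this note shows. Statements on the series, on what has been measured and on what is new or still open speak of the compounds shown alone.

Of the compounds shown here, two have been measured in an ADME assay on HepG2 cells (Homo sapiens) for cytotoxicity, read by luminescence, CellTiter-Glo and ATP content, with a stated time of 72 h; a lower number here means that less compound is needed, a higher number that more compound is needed for the effect. Compound 1, `COc1cccc(CNCCCNc2ccnc3cc(Oc4ccccc4)ccc23)c1O`, gives 6800 nM in this assay. Compound 2, `FC(F)(F)c1ccc(-c2ccc3c(NCCCNCc4ccco4)ccnc3c2)cc1`, gives 3470 nM in this assay. Among the compounds with values here, the two numbers sit within the usual scatter of each other, so nothing separates them with confidence; compound 1 merely marks one end of this small pair, and no step between them can be read as real.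

Compound 3, `COc1cccc(CNCCCNc2ccnc3cc(-c4ccc(C(C)(C)C)cc4)ccc23)c1O`, has not yet been measured in this assay. It differs from compound 1 in one place: 4-(tert-butyl)phenyl in place of phenoxy on an aromatic carbon. Compound 2 also carries a directly attached aryl ring on its core, and its value in this assay is the only hint available for what a change of this kind might do.

Within the data shown here, no step between measured compounds is known here, so any expectation rests on thin ground. The estimated step from compound 1 to compound 3 is a 1.7-fold lower number from compound 1 to compound 3 (0.23 log units; within the scatter), a small move toward a lower number, not clearly beyond the scatter. Compound 3 is expected to give about 4000 nM in this assay, within a range from 1500 nM to 11000 nM.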

Compound 3, half-maximal effective concentration: 690 nM
For compound 3 the middle estimate is 5.8-fold (0.76 log units) above the measured one; measured number below the stated range.
By their numbers in this assay, from the lowest: compound 3; then compounds 2 and 1 (each within the scatter of the next).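

Within the data shown here, putting 4-(tert-butyl)phenyl in place of phenoxy on this aromatic carbon gives a 9.9-fold lower number from compound 1 to compound 3 (0.99 log units; beyond the scatter) in this assay, the first step in this set that lies beyond the scatter, and it shows that the number in this assay responds to what this position carries. The two earlier compounds could not show this, since they differ in more than one place and their values lie within the scatter of each other. The change also alters several things at once, replacing a group of 7 heavy atoms with one hydrogen-bond acceptor by an all-carbon group of 10 heavy atoms with none, and no measurement at hand says why the number moves.

The compounds shown leave open whether the step follows from losing the phenoxy oxygen or from gaining the tert-butyl group, and a plain phenyl ring at the same carbon would begin to separate the two. On these data alone, it also remains open how a carboxylic acid or an amine on that ring would read in this assay, and whether the step would hold with a different side chain on the shared core.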